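Compound 3 and the step to compound 4

This account rests on a few compounds, and the source may have more. Where it says the series, first, only, none or still open, it means among the compounds named here.

Measured in a physicochemical assay for solubility, read by HPLC, in simulated intestinal fluid, with a stated time of 16 h, tested at 125 ug/mL; on this read-out higher numbers stand for higher solubility and lower numbers for lower solubility:
Compound 1 `CNC(=O)c1cc(C(=O)NC2CC2)cn(Cc2ccc(OC)cc2)c1=O`: 263 ug/mL
Compound 2 `CNC(=O)c1cc(C(=O)NC2CC2)c(C)n(Cc2ccccc2)c1=O`: 577 ug/mL
Compound 3 `CNC(=O)c1cc(C(=O)NC2CC2)cn(Cc2cccc3[nH]ccc23)c1=O`: 17 ug/mL

Compound 3 has the lowest number of the three, well short of both others. The next compound is compound 4 `CNC(=O)c1cc(C(=O)NC2CC2)cn(Cc2ccccc2F)c1=O`, and the change is 2-fluorophenyl in place of 1H-indol-4-yl on a saturated chain carbon bound to an aromatic nitrogen with 2-fluorophenyl in place of 1H-indol-4-yl. Among the measured compounds shown here, one measured step bears on this, a 15-fold lower number from compound 1 to compound 3 (1.19 log units; beyond the scatter) and it is large, with 1H-indol-4-yl entering in place of 4-methoxyphenyl. Here 1H-indol-4-yl leaves instead, so a step of similar size towards a higher number is expected in this assay for this change. The expected step is a 15-fold higher number from compound 3 to compound 4 (1.17 log units; beyond the scatter) and it remains an estimate. Compound 4 is estimated at 250 ug/mL with a range from 100 ug/mL to 550 ug/mL on this expectation.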

Compound 4, solubility: 88 ug/mL
The estimate for compound 4 lay 2.8-fold (0.45 log units) above the measured number, and the stated range ends above it.
By their numbers in this assay, from the lowest: compound 3; then compound 4; then compound 1; then compound 2.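

At this place, on a saturated chain carbon bound to an aromatic nitrogen, this assay shows that 2-fluorophenyl regains only part of the drop seen with 1H-indol-4-yl, with a 5.2-fold higher number from compound 3 to compound 4 (0.71 log units; beyond the scatter) and yet a 3.0-fold lower number from compound 1 to compound 4 (0.48 log units; beyond the scatter) in the same series. The number therefore also falls when 4-methoxyphenyl gives way to a group other than 1H-indol-4-yl, and these three groups now stand in order, with 4-methoxyphenyl highest and 1H-indol-4-yl lowest.

From the compounds shown here alone, what an amine or a carboxylic acid in place of 2-fluorophenyl would give at this place stays open. Nothing available gives a reason for either step.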